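A Side Chain Replaces Hydroxy on the Shared Core

The source may hold more compounds than are shown below. What is called first, only, known or untested is meant among the compounds shown, and "the series" means these compounds.

Among the compounds with values here, in a functional assay on the whole organism for positive allosteric modulation, with Mus musculus as the target (on this read-out lower numbers stand for an effect already at smaller amounts and higher numbers for an effect only at larger amounts of compound), compound 1 `CCC(=O)N(c1ccc(Cl)c(Cl)c1)C1CCCC1O` gives 20 mg/kg, the only exact number among the three measured compounds. Compound 2 `CCC(=O)N(c1ccccc1Cl)C1CCCC1N(C)C` is reported only as a limit, > 50 mg/kg. Compound 3 `CCC(=O)N(c1ccc(C(C)=O)cc1)C1CCCC1N(C)C` is likewise reported only as a limit, > 50 mg/kg. Compound 4 `CCC(=O)N(c1ccc(Cl)c(Cl)c1)C1CCCC1N(C)CCCN(C)C` carries (3-(dimethylamino)propyl)(methyl)amino in place of hydroxy on a saturated ring carbon. Within the data shown here, no measured step tests this change. Among the measured compounds shown here, the only other data are compound 2 and compound 3, which both sit at the limit of > 50 mg/kg in this assay, at which 2 of the 3 values shown sit. With that in view, a modest shift toward larger doses is expected in this assay, estimated as a 1.8-fold higher number from compound 1 to compound 4 (0.24 log units; within the scatter). For compound 4, the expected value is 35 mg/kg, with an estimated range of 12 mg/kg to 90 mg/kg.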

Compound 4, dose for half-maximal effect: 30 mg/kg
Beside the measured number, compound 4's estimate is 1.2-fold (0.07 log units) above it, and the stated range covers the measured number.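

Within the data shown here, the first step at this position shows that (3-(dimethylamino)propyl)(methyl)amino in place of hydroxy on a saturated ring carbon gives a 1.5-fold higher number from compound 1 to compound 4 (0.18 log units; within the scatter) in this assay. On the core of compound 1, this much larger chain therefore leaves the read-out within the usual scatter. Compound 4 has an exact number and does not join the values at: the limit of > 50 mg/kg in this assay, at which 2 of the 4 values shown sit.

The compounds shown leave open what a primary amine or a carboxylic acid would give at this ring carbon on the same core. They also leave open whether a longer chain would keep the read-out within the scatter.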